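Swapping the group on the sulfonyl sulfur

The source may report more compounds than this note shows. Statements on the series, on what has been measured and on what is new or still open speak of the compounds shown alone.

- compound 1 `CC(C)n1cc(S(=O)(=O)c2ccc(CNC(=O)N3Cc4ccncc4C3)cc2)cn1`: 4 mL/min/kg
- compound 2 `O=C(NCc1ccc(S(=O)(=O)C2CCCCC2)cc1)N1Cc2ccncc2C1`: 16 mL/min/kg
- compound 3 `O=C(NCc1ccc(S(=O)(=O)C2CCCOC2)cc1)N1Cc2ccncc2C1`: 7 mL/min/kg

In an ADME assay on microsomes from liver (Homo sapiens) for pharmacokinetics, read by LC-MS, with a stated time of 60 min, tested at 1 uM (on this read-out lower numbers stand for slow clearance and higher numbers for fast clearance), compound 3 gives 7 mL/min/kg. Its place is set by two steps: a 1.8-fold higher number from compound 1 to compound 3 (0.24 log units; within the scatter) stays within the scatter, while a 2.3-fold lower number from compound 2 to compound 3 (0.36 log units; beyond the scatter) goes modestly beyond it. The next change leads to compound 4 `CN1CCN(S(=O)(=O)c2ccc(CNC(=O)N3Cc4ccncc4C3)cc2)CC1`: 4-methylpiperazin-1-yl in place of oxan-3-yl on a sulfonyl sulfur. All three measured steps change the group at this same place, though none brings in 4-methylpiperazin-1-yl. The largest, a 4.0-fold higher number from compound 1 to compound 2 (0.60 log units; beyond the scatter), is modest. No step beyond the scatter is therefore expected, and the estimated step is a 1.1-fold higher number from compound 3 to compound 4 (0.06 log units; within the scatter). Compound 4 is expected at 8 mL/min/kg, within an estimated range of 4 mL/min/kg to 16 mL/min/kg.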

Compound 4, clearance: 9 mL/min/kg
Beside the measured number, compound 4's estimate is 1.1-fold (0.05 log units) below it; the range from low to high includes it.
By their numbers in this assay, from the lowest: compounds 1, 3, 4 and 2 (each within the scatter of the next, the first and the last beyond it).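

In this assay, 4-methylpiperazin-1-yl, with two hetero atoms in its ring, cannot be told apart from oxan-3-yl (a 1.3-fold higher number from compound 3 to compound 4 (0.11 log units; within the scatter)) or from cyclohexyl (a 1.8-fold lower number from compound 2 to compound 4 (0.25 log units; within the scatter)), as both steps lie within the scatter. Against 1-isopropyl-1H-pyrazol-4-yl, the step of a 2.3-fold higher number from compound 1 to compound 4 (0.35 log units; beyond the scatter) goes modestly beyond the scatter, so compound 4 separates from compound 1 as compound 2 does, while compound 3 does not. Nothing available bears on the reason for these numbers.

Open, going by these compounds, is whether morpholin-4-yl, piperazin-1-yl without the methyl or an open alkyl chain on the sulfonyl sulfur would stay close to compound 1 at 4 mL/min/kg. On these data alone, the effect of changes elsewhere on the shared core also remains open.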